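Hydroxy in place of chloro: working notes on the series

The source may report more compounds than this note shows. Statements on the series, on what has been measured and on what is new or still open speak of the compounds shown alone.

Measured in a functional assay on SW-620 cells (Homo sapiens) for cytotoxicity, read by MTT assay, with a stated time of 72 h; on this read-out lower numbers stand for stronger inhibition and higher numbers for weaker inhibition:
- compound 1 `COc1ccc(/C=C2\CCC/C(=C\c3ccccc3Br)C2=O)cc1OC`: 5300 nM
- compound 2 `COc1ccc(/C=C2\CCC/C(=C\c3ccc(Cl)c(Cl)c3)C2=O)cc1OC`: 4000 nM

Going by the values given here, compound 2 has only one measured neighbour, and the single step available, a 1.3-fold lower number from compound 1 to compound 2 (0.12 log units; within the scatter), leaves the pair level within the scatter. Compound 3 `COc1ccc(/C=C2\CCC/C(=C\c3ccc(O)c(Cl)c3)C2=O)cc1OC` keeps the rest of compound 2 and differs at one place: hydroxy in place of chloro on an aromatic carbon. The same difference reads 3,4-dichlorophenyl to 3-chloro-4-hydroxyphenyl. Among the compounds with values here, no measured compound carries hydroxy, so the data hold no direct precedent. Within the data shown here, the one measured step bears on this change only loosely, as it shows that one change of this group left the number within the scatter. No shift beyond the scatter is therefore expected in this assay, and no direction can be favoured. The expected change is a 1.1-fold lower number from compound 2 to compound 3 (0.02 log units; within the scatter). For compound 3 the estimated value is 3800 nM, with an expected range of 1500 nM to 10000 nM.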

Compound 3, half-maximal inhibitory concentration: 7100 nM
Estimate against measurement, compound 3: 1.9-fold (0.27 log units) below; the range from low to high includes it.
By their numbers in this assay, from the lowest: compounds 2, 1 and 3 (each within the scatter of the next).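

In this assay the position that carried chloro now has its first direct test: hydroxy, which unlike chloro counts as a hydrogen-bond donor and acceptor, leaves the pair level within the scatter (a 1.8-fold higher number from compound 2 to compound 3 (0.25 log units; within the scatter)). The step from the 2-bromophenyl compound reads the same way (a 1.3-fold higher number from compound 1 to compound 3 (0.13 log units; within the scatter)), so 2-bromophenyl, 3,4-dichlorophenyl and 3-chloro-4-hydroxyphenyl cannot be separated in this assay. No measured property of these groups is at hand to bear on this result.

On these data alone, whether an amino group or a carboxylic acid on this aromatic carbon would also stay within the scatter remains open. Also open, as far as these compounds go, is whether hydroxy would read the same without the chloro group beside which it sits in compound 3.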